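This account rests on a few compounds, and the source may have more. Where it says the series, first, only, none or still open, it means among the compounds named here.

Working notes on the series. Compound 1 `COCCOC(=O)N1CCC(Oc2ncnc3c2CCN3c2ccc(S(C)(=O)=O)cc2F)CC1` and compound 2 `CS(=O)(=O)c1ccc(N2CCc3c(OC4CCN(C(=S)Sc5ccccc5)CC4)ncnc32)c(F)c1` share one core and differ only at the amine nitrogen in a ring. In a functional assay on CHO-K1 cells with Glucose-dependent insulinotropic receptor (Homo sapiens) as the target, read by a luciferase reporter, with a stated time of 5 h (on this read-out higher numbers stand for larger maximal responses and lower numbers for smaller maximal responses), compound 1 gives 86% and compound 2 gives 103%. Their structural difference, a group of 9 heavy atoms (7 carbon, 2 sulfur; one six-membered aromatic ring of carbon only) in place of a group of 7 heavy atoms (4 carbon, 3 oxygen; no ring), gave a number 17 percentage points higher from compound 1 to compound 2 (beyond the scatter). Compound 2 thus stands highest of the two numbers measured, compound 1 being the nearest and lower beyond the scatter.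

Compound 3 `CCS(=O)(=O)N1CCC(Oc2ncnc3c2CCN3c2ccc(S(C)(=O)=O)cc2F)CC1` is not yet measured in this assay. It differs from compound 2 by a group of 5 heavy atoms (2 carbon, 2 oxygen, 1 sulfur; no ring) in place of a group of 9 heavy atoms (7 carbon, 2 sulfur; one six-membered aromatic ring of carbon only), on an amine nitrogen in a ring. Within the data shown here, the only measured step, a number 17 percentage points higher from compound 1 to compound 2 (beyond the scatter), went from a group without a ring to the group carrying the aromatic ring; the step to compound 3 returns to a group without a ring, ethylsulfonyl, which has no counterpart among the measured compounds. That single comparison points weakly downward, so a step of about a number 13 percentage points lower from compound 2 to compound 3 (beyond the scatter) in this assay is expected. For compound 3 the estimate in this assay is 90%, within a range from 74% to 106%.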

Compound 3, largest response reached (reported as percent of maximum), in percent of the reference or control that the assay uses: 51%
Estimate against measurement, compound 3: 39 percentage points above; the measured number lies below the stated range.
By their numbers in this assay, from the lowest: compound 3; then compound 1; then compound 2.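

In this assay the amine nitrogen in a ring tolerates less change than the earlier pair suggested: ethylsulfonyl in place of the group carrying the aromatic ring gives a number 52 percentage points lower from compound 2 to compound 3 (beyond the scatter) and, against the other group without a ring, ethylsulfonyl in place of (2-methoxyethoxy)carbonyl gives a number 35 percentage points lower from compound 1 to compound 3 (beyond the scatter) in the same read-out. Absence of a ring therefore does not set the response on its own, since compound 1 and compound 3 both lack a ring in this group and still lie apart beyond the scatter, and the fall from compound 2 to compound 3 comes with no change in the counts of hydrogen-bond donors and acceptors. Nothing available on these compounds bears on why the maximal response changes at this position.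

As far as these compounds go, what remains open is whether the lower number of compound 3 goes with the sulfonyl link or with the short ethyl chain, which a phenylsulfonyl group on the same nitrogen would help to separate. A phenoxycarbonyl group would likewise show whether the higher number of compound 2 follows the benzene ring or the sulfur-containing link that carries it.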